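Methoxy for Trifluoromethyl on Two Related Cores

A few compounds are considered here, and "the series" means these few. Any claim that something is new, unique, unknown or untested is made for them only; others in the source may bear on it.

Measured so far in an ADME assay on THP-1 cells (Homo sapiens) for cytotoxicity; a higher number here means that more compound is tolerated, a lower number that less compound is tolerated:
compound 1 `Fc1ccc(Nc2c(-c3ccccn3)nc3ccc(C(F)(F)F)cn23)cc1`: > 50000 nM, a limit of the assay, not a number
compound 2 `COc1ccc2nc(-c3ccccn3)c(Nc3ccc(F)cc3)n2c1`: 4260 nM
compound 3 `Fc1ccc(Nc2c(-c3ccccn3)nc3cc(C(F)(F)F)ccn23)cc1`: 23700 nM

Compound 2 arises from compound 1 by methoxy in place of trifluoromethyl on an aromatic carbon, a change that gave an at least 11-fold lower number from compound 1 to compound 2 (1.06 log units; beyond the scatter); the value of compound 1 sits at the limit of > 50000 nM in this assay, at which 1 of the 3 values shown sits. Compound 3 shares its atoms with compound 1, joined differently, and the difference between the two cores is not broken down here. Compound 4 `COc1ccn2c(Nc3ccc(F)cc3)c(-c3ccccn3)nc2c1` arises from compound 3 by methoxy in place of trifluoromethyl on an aromatic carbon, the same kind of change, the place differing in that it is opposite the ring nitrogen rather than two atoms from it. In this assay the step is expected to be a 4.7-fold lower number from compound 3 to compound 4 (0.68 log units; beyond the scatter), resting on the step from compound 1 to compound 2, an at least 11-fold lower number from compound 1 to compound 2 (1.06 log units; beyond the scatter). Compound 4 is therefore estimated at 5000 nM, between 1500 nM and 15000 nM.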

Compound 4, half-maximal cytotoxic concentration: 4560 nM
Compound 4: the middle estimate sits 1.1-fold (0.04 log units) above what was measured; low and high end bracket the measured number.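

In this assay, methoxy in place of trifluoromethyl gave a 5.2-fold lower number from compound 3 to compound 4 (0.72 log units; beyond the scatter), so the number fell on this core in the same direction as on the core of compound 1: the same change on two cores in this assay, an at least 11-fold lower number (1.06 log units; beyond the scatter) from compound 1 to compound 2 and a 5.2-fold lower number (0.72 log units; beyond the scatter) from compound 3 to compound 4; the limit leaves it open whether they differ. The value of compound 1 is a limit of the assay and not a number: the limit of > 50000 nM in this assay, at which 1 of the 4 values shown sits. The direction of the change therefore held on both cores, but these two pairs do not show that the size of the step carries from one core to the other.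

The compounds shown leave open how an amine, a nitrile or a longer chain would fare in place of methoxy. They also leave open whether any difference between the steps follows the place of the group on the ring or the rest of the core.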